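Hydroxycarbamoyl replacement carried onto a second core

A few compounds are considered here, and "the series" means these few. Any claim that something is new, unique, unknown or untested is made for them only; others in the source may bear on it.

Three compounds of the series have numbers in a functional assay on SK-HEP1 cells (Homo sapiens) for inhibition, read by MTT assay, with a stated time of 72 h; on this read-out lower numbers stand for stronger inhibition and higher numbers for weaker inhibition. Compound 1 `CNC(=O)CCCCCCCn1nc(-c2cnc3[nH]ccc3c2)c2c(N)ncnc21` gives 3950 nM. Compound 2 `Nc1ncnc2c1c(-c1cnc3[nH]ccc3c1)nn2CCCCCCC(=O)NO` differs from compound 1 by hydroxycarbamoyl in place of (methylcarbamoyl)methyl on a saturated chain carbon, six bonds along the chain from an aromatic nitrogen, and in this assay compound 2 gives 14700 nM, a step of a 3.7-fold higher number from compound 1 to compound 2 (0.57 log units; beyond the scatter). Compound 3 `CNC(=O)CCCCCCCn1nc(-c2ccc3oc(N)nc3c2)c2c(N)ncnc21` carries a different core, the difference being (a group of 10 heavy atoms (7 carbon, 2 nitrogen, 1 oxygen; one five-membered aromatic ring with 2 hetero atoms, one six-membered aromatic ring of carbon only) in place of a group of 9 heavy atoms (7 carbon, 2 nitrogen; one five-membered aromatic ring with 1 hetero atom, one six-membered aromatic ring with 1 hetero atom), on an aromatic carbon); in this assay compound 3 gives 10700 nM, which is a 2.7-fold higher number from compound 1 to compound 3 (0.43 log units; beyond the scatter). The numbers of compound 2 and compound 3 lie within the scatter of each other.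

Compound 4 `Nc1nc2cc(-c3nn(CCCCCCC(=O)NO)c4ncnc(N)c34)ccc2o1` is not yet measured. It differs from compound 3 by hydroxycarbamoyl in place of (methylcarbamoyl)methyl on a saturated chain carbon, six bonds along the chain from an aromatic nitrogen, the same change as that between compound 1 and compound 2, with the place described in identical words for both pairs. For the measured compounds named here, the step from compound 3 to compound 4 is expected to be similar in size, estimated as a 3.7-fold higher number from compound 3 to compound 4 (0.57 log units; beyond the scatter), because the only precedent in this assay is a 3.7-fold higher number from compound 1 to compound 2 (0.57 log units; beyond the scatter). Compound 4 is therefore expected to give about 40000 nM, with a range from 15000 nM to 100000 nM. Given where compound 3 already stands, the assay may report only a limit for compound 4 rather than a number.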

Compound 4, half-maximal inhibitory concentration: 2690 nM
The estimate for compound 4 lay 15-fold (1.17 log units) above the measured number; measured number below the stated range.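

In this assay the replacement of (methylcarbamoyl)methyl by hydroxycarbamoyl does not carry over from one core to the other; on the core of compound 3 it gives a 4.0-fold lower number from compound 3 to compound 4 (0.60 log units; beyond the scatter), opposite in direction to the earlier step on the core of compound 1: the same change on two cores in this assay, a 3.7-fold higher number (0.57 log units; beyond the scatter) from compound 1 to compound 2 and a 4.0-fold lower number (0.60 log units; beyond the scatter) from compound 3 to compound 4, 15-fold (1.17 log units) apart, beyond the scatter of two such steps. Read the other way, the core change made on the hydroxycarbamoyl chain gives a 5.5-fold lower number from compound 2 to compound 4 (0.74 log units; beyond the scatter), whereas the same core change on the methylcarbamoyl chain raised the number: the same change on two cores in this assay, a 2.7-fold higher number (0.43 log units; beyond the scatter) from compound 1 to compound 3 and a 5.5-fold lower number (0.74 log units; beyond the scatter) from compound 2 to compound 4, 15-fold (1.17 log units) apart, beyond the scatter of two such steps. For the compounds shown here, the two changes therefore do not add independently in these four compounds, but with only one pair on each core this does not show what underlies the reversal or how either change would behave on a further core.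

Going by these compounds, it remains open whether the lower number of compound 4 holds with a shorter or longer chain, or with a carboxylic acid or a primary amide in place of hydroxycarbamoyl. Also open, on these data alone, is whether the reversal appears in a second cell line.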